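The source may report more compounds than this note shows. Statements on the series, on what has been measured and on what is new or still open speak of the compounds shown alone.

Measured compounds:
- compound 1, `COc1ccc2c(=O)c(/C=C/C(=O)NCc3ccccc3)coc2c1`, 376000 nM in an ADME assay on HepG2 2.2.15 cells (Homo sapiens) for cytotoxicity, read by MTT assay, with stated times of 48 h and 9 days; a lower number here means that less compound is tolerated, a higher number that more compound is tolerated
- compound 2, `O=C(/C=C/c1coc2cc(O)ccc2c1=O)Nc1ccccc1`, 821000 nM in this assay

Both numbers come from this assay. Compound 1 gives the lower of the two values in this assay, and the value of compound 2 lies above it by more than the usual scatter, so compound 2 is tolerated at a higher concentration than compound 1. The two differ in more than one place, so nothing can be said about which part of their structures accounts for the gap.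

Compound 3, `COc1ccc2c(=O)c(/C=C/C(=O)NCc3ccc(F)cc3F)coc2c1`, has not yet been measured in this assay. It differs from compound 1 in a single spot: 2,4-difluorophenyl in place of phenyl on a saturated chain carbon bound to an amide-type nitrogen. Among the compounds with values here, no measured pair shows this exact change, so there is no direct guide for its effect. Both compounds are tolerated only at high concentrations, and a swap of this kind is expected to move the number little, if at all, beyond the scatter. The step of a 1.1-fold lower number from compound 1 to compound 3 (0.03 log units; within the scatter) is therefore expected to be small, with no clear direction. Compound 3 is estimated at 350000 nM, within a range of 150000 nM to 800000 nM.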

Compound 3, half-maximal cytotoxic concentration: 79300 nM
Compound 3: middle estimate off by 4.4-fold (0.64 log units), on the high side; the whole stated range lies above it.
By their numbers in this assay, from the lowest: compound 3; then compound 1; then compound 2.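

In this assay, going from benzyl to 2,4-difluorobenzyl gives a 4.7-fold lower number from compound 1 to compound 3 (0.68 log units; beyond the scatter). Within the data shown here, this is the first comparison here in which only one place differs, and it shows that this position is not a silent one: with the rest of the structure unchanged, adding two fluorine atoms to the ring is enough for the cells to tolerate less compound, a modest shift but one that lies beyond the usual scatter. Nothing on hand explains this drop.

Going by these compounds, it remains open whether the shift comes from having fluorine on the ring at all, from having two fluorines, or from where they sit. A ring bearing a single fluorine, a chlorine or a methoxy group at this place, or a cyclohexyl group instead of the ring, would help show whether the tolerated concentration follows the kind of group or responds to almost any change here.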